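Swapping the Ethoxycarbonyl Group for Hydroxymethyl

The compounds below may be only part of what the source reports. "The series", "measured", "known", "first", "only" and "open" are said of these compounds alone.

In a functional assay on DU-145 cells (Homo sapiens) for cytotoxicity, read by MTT assay, with a stated time of 72 h (on this read-out lower numbers stand for an effect already at smaller amounts and higher numbers for an effect only at larger amounts of compound), compound 1 `CCOC(=O)c1c(C)coc1-c1ccc2c(CC)cccc2c1OC` gives 2.2 ug/mL. The related compound 3 `CCOc1c(-c2occ(C)c2C(=O)OC)ccc2c(CC)cccc12` gives 1.9 ug/mL, and these two values lie within the scatter of each other. Compound 2 `CCc1cccc2c(OC)c(-c3occ(C)c3C(=O)On3nnc4ccccc43)ccc12` reports only a limit, > 10 ug/mL. Among the measured compounds shown here, compound 1 therefore sits with compound 3 as one of only two measured numbers, and neither can be ranked above the other.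

Compound 4 `CCc1cccc2c(OC)c(-c3occ(C)c3CO)ccc12` keeps the core of compound 1 but carries hydroxymethyl in place of ethoxycarbonyl on an aromatic carbon.

For the measured compounds named here, only one measured step touches this group. It is an at least 4.5-fold higher number from compound 1 to compound 2 (0.65 log units; beyond the scatter), a change beyond the scatter that keeps the carbonyl and replaces the ethyl end of the ester with a much larger group. Going by the values given here, that step shows that the number can respond to a change here, but it is a different kind of change, and no measured compound lacks the ester. Hydroxymethyl is a small group, so a jump as large as the one to compound 2 is not assumed. A modest upward step is expected, a 1.6-fold higher number from compound 1 to compound 4 (0.20 log units; within the scatter), and it may not clear the scatter. Compound 4 is estimated at 3.5 ug/mL, with an expected range of 1.3 ug/mL to 9 ug/mL.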

Compound 4, concentration for half-maximal effect: 7.2 ug/mL
Estimate against measurement, compound 4: 2.1-fold (0.31 log units) below; the range from low to high includes it.
By their numbers in this assay, from the lowest: compounds 3 and 1 (each within the scatter of the next); then compound 4. At a limit, above all of these: compound 2.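

In this assay, removing the ester altogether and setting hydroxymethyl on the same aromatic carbon gives a 3.3-fold higher number from compound 1 to compound 4 (0.51 log units; beyond the scatter), so a compound without the ester still has a number, but only at a larger amount of compound. Among the compounds shown here, until now, the only measured change at this place was the one to compound 2, whose value is a limit and not a number. This step shows that a group smaller than ethoxycarbonyl can also raise the number beyond the scatter, but no measurement shown here speaks to why it rises.

In compound 4 the loss of the carbonyl and the arrival of the hydroxyl come together, and the compounds shown cannot separate these two parts of the change. As far as these compounds go, a carboxylic acid, an amide or a methoxymethyl group on this aromatic carbon would help to pull them apart, and how any of these reads in this assay remains open.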